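Changing the Sulfonyl Substituent of an Inactive Sulfonamide

The source may report more compounds than this note shows. Statements on the series, on what has been measured and on what is new or still open speak of the compounds shown alone.

The series rests on a shared core carrying an arylsulfonamide at its far end. In an assay on cells for antagonist activity at transient receptor potential cation channel subfamily V member 1 (Homo sapiens), read by FLIPR and calcium flux, with a stated time of 15 min (on this read-out higher numbers stand for weaker inhibition and lower numbers for stronger inhibition), compound 1 `CC1CCN(c2nc(C(F)(F)F)ccc2CNC(=O)C(C)c2cc(F)c(NS(C)(=O)=O)c(Br)c2)CC1` gives 0.7 nM, and compound 2 `COc1cc(C(C)C(=O)NCc2ccc(C(F)(F)F)nc2N2CCC(C)CC2)ccc1NS(C)(=O)=O` gives 0.8 nM; the two values lie within the usual scatter of each other. Compound 3 `CC1CCN(c2nc(C(F)(F)F)ccc2CNC(=O)C(C)c2ccc(NS(=O)(=O)C(F)(F)F)c(F)c2)CC1` stands apart: in this assay compound 3 is reported as "not active" (no number reported), and no single number is given for it, so there is no value from which a step can be measured.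

Compound 4 `CC1CCN(c2nc(C(F)(F)F)ccc2CNC(=O)C(C)c2ccc(NS(=O)(=O)N(C)C)c(F)c2)CC1` is built from compound 3 with one change, (dimethylamino in place of trifluoromethyl on a sulfonyl sulfur). Among the measured compounds shown here, since no step between measured compounds covers this change, its size in this assay cannot be read from the data, and the account can only say that compound 3 showed no activity while compound 4 carries a different group on the sulfonyl sulfur. Given that compound 3 returned "not active" (no number reported), compound 4 is expected to lie well away from the values of compound 1 and compound 2, with a broad band of uncertainty. The estimate for compound 4 in this assay is 40 nM, with a range from 2 nM to 1500 nM.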

Compound 4, inhibition constant: 42 nM
For compound 4 the middle estimate is 1.1-fold (0.02 log units) below the measured one, and the stated range covers the measured number.
By their numbers in this assay, from the lowest: compounds 1 and 2 (each within the scatter of the next); then compound 4.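

In this assay, among the compounds shown here, compound 4 gives 42 nM while compound 3 is recorded as "not active" (no number reported) and so no step between compound 3 and compound 4 can be read. The compounds shown leave open how large the change from trifluoromethyl to dimethylamino on the sulfonyl sulfur is, and whether it holds elsewhere in the series. Nothing shown here accounts for the result.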